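A few compounds are considered here, and "the series" means these few. Any claim that something is new, unique, unknown or untested is made for them only; others in the source may bear on it.

Working notes on the series. The shared core is that of compound 1, `COCC#Cc1cc(C(O)(C(F)(F)F)C(F)(F)F)cnc1N1CCN(S(=O)(=O)c2ccc(N)nc2)CC1`, followed in an ADME assay (liver) for metabolic stability, with Liver microsome (Rattus norvegicus) as the target, using microsomes and NADPH, with a stated time of 30 min, tested at 1 uM; a higher number here means faster removal of the compound, a lower number slower removal. In this assay, within the data shown here, compound 1 gives 399 mL.min-1.g-1, the highest of the three numbers measured so far. Compound 2, `CCn1cc(-c2cc(C(O)(C(F)(F)F)C(F)(F)F)cnc2N2CCN(S(=O)(=O)c3ccc(N)nc3)CC2)cn1`, gives 194 mL.min-1.g-1, and compound 3, `CC(C)n1cc(-c2cc(C(O)(C(F)(F)F)C(F)(F)F)cnc2N2CCN(S(=O)(=O)c3ccc(N)nc3)CC2)cn1`, gives 198 mL.min-1.g-1. The measured steps are a 2.1-fold lower number from compound 1 to compound 2 (0.31 log units; beyond the scatter) and a 2.0-fold lower number from compound 1 to compound 3 (0.30 log units; within the scatter), while between the two pyrazoles there is a 1.0-fold higher number from compound 2 to compound 3 (0.01 log units; within the scatter).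

Compound 4, `Nc1ccc(S(=O)(=O)N2CCN(c3ncc(C(O)(C(F)(F)F)C(F)(F)F)cc3-c3cnccc3F)CC2)cn1`, is not yet measured. It differs from compound 1 by 4-fluoropyridin-3-yl in place of 3-methoxyprop-1-yn-1-yl on an aromatic carbon. Among the measured compounds shown here, the steps that bear on it, a 2.1-fold lower number from compound 1 to compound 2 (0.31 log units; beyond the scatter) and a 2.0-fold lower number from compound 1 to compound 3 (0.30 log units; within the scatter), each replace the same 3-methoxyprop-1-yn-1-yl with an aromatic ring and each lower the number by about the same amount, one of them just beyond the scatter and the other just within it. A step of similar size and direction is therefore expected here, estimated as a 1.8-fold lower number from compound 1 to compound 4 (0.26 log units; within the scatter). Compound 4 is expected to give 220 mL.min-1.g-1 in this assay, with a range of 120 mL.min-1.g-1 to 400 mL.min-1.g-1.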

Compound 4, intrinsic clearance in microsomes: 22 mL.min-1.g-1
Estimate against measurement, compound 4: 10-fold (1.00 log units) above, outside the stated range (below it).
By their numbers in this assay, from the lowest: compound 4; then compounds 2, 3 and 1 (each within the scatter of the next, the first and the last beyond it).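

At this position, on an aromatic carbon two atoms from the ring nitrogen, the identity of the entering ring matters in this assay: 4-fluoropyridin-3-yl in place of 3-methoxyprop-1-yn-1-yl gives an 18-fold lower number from compound 1 to compound 4 (1.26 log units; beyond the scatter) and so stands well apart from the two pyrazole replacements. Exchanging one aromatic ring for another also moves the number, with an 8.8-fold lower number from compound 2 to compound 4 (0.95 log units; beyond the scatter) and a 9.0-fold lower number from compound 3 to compound 4 (0.95 log units; beyond the scatter), so the presence of an aromatic ring alone does not account for the result. The compounds shown come with no measurement that explains why 4-fluoropyridin-3-yl differs from the pyrazoles.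

The compounds shown do not separate the contribution of the ring nitrogen from that of the fluorine, for which an unsubstituted phenyl, a 4-fluorophenyl or a pyridin-3-yl would be the direct comparisons. Also open, on these data alone, is how an amine or a carboxylic acid would read at this position.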